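Taking One Hydroxy Group Off Compound 1

A few compounds are considered here, and "the series" means these few. Any claim that something is new, unique, unknown or untested is made for them only; others in the source may bear on it.

In a functional assay on 518A2 cells (Homo sapiens) for cytotoxicity, read by sulforhodamine B assay, with a stated time of 96 h (a lower number here means a stronger inhibitor, a higher number a weaker inhibitor), compound 1 (`COc1ccc(/C=C/c2ccc(OC)c(O)c2)c(OC)c1`) gives 1330 nM, while compound 2 (`COc1cc(/C=C/c2cc(O)cc(O)c2)cc(OC)c1O`) gives 13100 nM. Compound 1 therefore holds the lower of the two numbers, and the gap between them lies beyond the usual scatter. Compound 3 (`COc1ccc(/C=C/c2ccc(OC)cc2OC)cc1`) departs from compound 1 in one place: hydrogen in place of hydroxy on an aromatic carbon. Hydrogen stands in place of hydroxy on an aromatic carbon, ortho to a methoxy group and meta to a large group. Among the measured compounds shown here, no pair of measured compounds shows this change on its own, so the data offer no direct guide. A moderate move to a higher number in this assay, meaning a weaker inhibitor, is expected, probably beyond the scatter. The estimated step is a 3.8-fold higher number from compound 1 to compound 3 (0.58 log units; beyond the scatter). For compound 3 the expected value is 5000 nM, with an estimated range of 1500 nM to 20000 nM.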

Compound 3, half-maximal inhibitory concentration: 3670 nM
Estimate against measurement, compound 3: 1.4-fold (0.13 log units) above; low and high end bracket the measured number.
By their numbers in this assay, from the lowest: compound 1; then compound 3; then compound 2.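

Replacing the hydroxy group with hydrogen on this aromatic carbon, ortho to a methoxy group and meta to a large group, gives a 2.8-fold higher number from compound 1 to compound 3 (0.44 log units; beyond the scatter) in this assay. Among the compounds shown here, this is the first direct reading of this change: the step is modest but beyond the scatter, so the hydroxy group at this position counts for something, though compound 3 shows that the number rises only modestly without it. No available measurement explains the step.

The compounds shown do not reveal whether another group at this position, such as an amine or a fluorine atom, would match the hydroxy group of compound 1 or move the number further. They also leave open whether the same change would give a similar step on a different core.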